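Removing a pyrrolidinylmethyl group from a potent enzyme inhibitor

The compounds below may be only part of what the source reports. "The series", "measured", "known", "first", "only" and "open" are said of these compounds alone.

Of the compounds shown here, three that share a common core have been tested in an assay for inhibition of Fatty-acid amide hydrolase 1 (Rattus norvegicus); a lower number here means a stronger inhibitor, a higher number a weaker inhibitor. Compound 1 `CCOC(=O)c1cccc(-c2cnc(C(=O)CCc3ccc(-c4ccccc4)cc3)o2)n1` gives 3 nM in this assay, and compound 2 `COC(=O)c1ccc(-c2cnc(C(=O)CCc3ccc(-c4ccccc4)cc3)o2)cn1` gives 0.6 nM. Compound 3 `COC(=O)c1cccc(-c2cnc(C(=O)CCc3ccc(-c4ccc(CN5CCCC5)cc4)cc3)o2)n1` gives 18 nM, which is the highest number of the three: compound 1 comes closest, and compound 2 lies furthest away, both gaps reaching beyond the usual scatter of such measurements.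

Compound 4 `COC(=O)c1cccc(-c2cnc(C(=O)CCc3ccc(-c4ccccc4)cc3)o2)n1` has not yet been measured in this assay. It differs from compound 3 in one place: hydrogen in place of (pyrrolidin-1-yl)methyl on an aromatic carbon

Among the measured compounds, the two that carry a plain phenyl at this position, compound 1 with 3 nM and compound 2 with 0.6 nM, both give lower numbers than compound 3. The step from compound 3 to compound 4 is therefore expected to be a clear fall in the number, a 6.0-fold lower number from compound 3 to compound 4 (0.78 log units; beyond the scatter), beyond the scatter. Compound 4 is estimated to give 3 nM in this assay, with a likely range from 1 nM to 9 nM.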

Compound 4, inhibition constant: 1.2 nM
The estimate for compound 4 lay 2.5-fold (0.40 log units) above the measured number; measured number inside the range.
By their numbers in this assay, from the lowest: compounds 2 and 4 (each within the scatter of the next); then compound 1; then compound 3.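

Taking away the (pyrrolidin-1-yl)methyl group gives a 15-fold lower number from compound 3 to compound 4 (1.18 log units; beyond the scatter) in this assay, so this single change, read directly for the first time, shows that the group carries a large penalty at this aromatic carbon. The other changes weigh less: 6-(methoxycarbonyl)pyridin-2-yl in place of 6-(methoxycarbonyl)pyridin-3-yl gives a 2.0-fold higher number from compound 2 to compound 4 (0.30 log units; within the scatter), while hydrogen in place of methyl on the saturated chain carbon bound to the ester oxygen gives a modest 2.5-fold lower number from compound 1 to compound 4 (0.40 log units; beyond the scatter). Nothing shown here accounts for the size of the large step.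

The compounds shown leave open whether this penalty belongs to the pyrrolidine ring or to any group on this carbon. A smaller dimethylaminomethyl group, a hydroxymethyl group or a carboxylic acid in the same place would help to separate these possibilities.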